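Chloro for Methyl: An Expected Cytotoxicity Reading

The source may report more compounds than this note shows. Statements on the series, on what has been measured and on what is new or still open speak of the compounds shown alone.

Going by the values given here, compound 2 `COC(=O)c1c(C)cccc1OC(=O)COc1cc(O)c2c(=O)cc(-c3ccccc3)oc2c1` gives 298000 nM in an ADME assay on cells (T-cell, Mus musculus, strain BALB/c) for cytotoxicity, read by MTT assay, with a stated time of 48 h (on this read-out lower numbers stand for higher toxicity in this test and higher numbers for lower toxicity in this test), the highest of two numbers so far, and compound 1 `COC(=O)c1cc(O)ccc1OC(=O)COc1cc(O)c2c(=O)cc(-c3ccccc3)oc2c1` gives 263000 nM, a difference described as a 1.1-fold higher number from compound 1 to compound 2 (0.05 log units; within the scatter). Compound 3 `COC(=O)c1c(Cl)cccc1OC(=O)COc1cc(O)c2c(=O)cc(-c3ccccc3)oc2c1` differs from compound 2 by chloro in place of methyl on an aromatic carbon. Among the compounds with values here, no measured step involves chloro in place of methyl, so the only guidance is that the one measured step stayed within the scatter. Compound 3 is therefore expected to give 290000 nM, with a range from 150000 nM to 560000 nM, a step of a 1.0-fold lower number from compound 2 to compound 3 (0.01 log units; within the scatter) expected to stay within the scatter.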

Compound 3, half-maximal cytotoxic concentration: 366000 nM
For compound 3 the middle estimate is 1.3-fold (0.10 log units) below the measured one, and the stated range covers the measured number.
By their numbers in this assay, from the lowest: compounds 1, 2 and 3 (each within the scatter of the next).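

In this assay, chloro in place of methyl on the aromatic carbon gives a 1.2-fold higher number from compound 2 to compound 3 (0.09 log units; within the scatter), so this position tolerates the swap without a reading that stands apart from compound 2. Changing compound 1 to the chloro group gives a 1.4-fold higher number from compound 1 to compound 3 (0.14 log units; within the scatter), so all three compounds remain indistinguishable in this test. Nothing available offers a reason for these readings. Still open, from the compounds shown here alone, is whether an amine or a carboxylic acid on this aromatic carbon would move the number beyond the scatter.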